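The source may hold more compounds than are shown below. What is called first, only, known or untested is meant among the compounds shown, and "the series" means these compounds.

Compound 1 `O=c1[nH]cc(S(=O)(=O)Nc2ccccc2-c2cn(-c3ccccc3Cl)nn2)c(=O)[nH]1` gives 22800 nM in an ADME assay on L02 cells (Homo sapiens) for cytotoxicity, read by MTT assay, with a stated time of 24 h; a higher number here means that more compound is tolerated, a lower number that less compound is tolerated.
Compound 2 `O=c1[nH]cc(S(=O)(=O)Nc2ccccc2-c2cn(-c3cccc(Cl)c3)nn2)c(=O)[nH]1` reaches only the limit > 100000 nM in this assay, which is not a number.
Compound 3 `O=c1[nH]cc(S(=O)(=O)Nc2ccc(-c3cn(-c4ccccc4Cl)nn3)cc2)c(=O)[nH]1` gives 19300 nM in this assay.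

The change from compound 1 to compound 2 is 3-chlorophenyl in place of 2-chlorophenyl on an aromatic nitrogen. It produced an at least 4.3-fold higher number from compound 1 to compound 2 (0.64 log units; beyond the scatter), a result shaped by the limit of > 100000 nM in this assay, at which 1 of the 3 values shown sits. Compound 3 and compound 1 share the same kind of building blocks joined differently, but the difference between the two cores is not broken down here; their two values sit within the scatter of each other. Compound 4 `O=c1[nH]cc(S(=O)(=O)Nc2ccc(-c3cn(-c4cccc(Cl)c4)nn3)cc2)c(=O)[nH]1` carries the same change relative to compound 3, namely (3-chlorophenyl in place of 2-chlorophenyl on an aromatic nitrogen). Placed beside the earlier step, compound 4 is expected to show a 4.7-fold higher number from compound 3 to compound 4 (0.67 log units; beyond the scatter), resting on compound 3 at 19300 nM and on the step of an at least 4.3-fold higher number from compound 1 to compound 2 (0.64 log units; beyond the scatter). Compound 4 is therefore estimated at 90000 nM, likely again at the limit.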

Compound 4, half-maximal cytotoxic concentration: 19000 nM
Compound 4: middle estimate off by 4.7-fold (0.68 log units), on the high side, outside the stated range (below it).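

In this assay, putting 3-chlorophenyl in place of 2-chlorophenyl gives a 1.0-fold lower number from compound 3 to compound 4 (0.01 log units; within the scatter), so on this core the change has no effect that can be told from scatter. The change therefore does not carry over unaltered from the core of compound 1 to the core of compound 3: the same change on two cores in this assay, an at least 4.3-fold higher number (0.64 log units; beyond the scatter) from compound 1 to compound 2 and a 1.0-fold lower number (0.01 log units; within the scatter) from compound 3 to compound 4, at least 4.4-fold (0.64 log units) apart, beyond the scatter of two such steps Compound 2 is the one at a limit, so the true size of the earlier step stays unknown, and two cores give no rule for a third: the limit of > 100000 nM in this assay, at which 1 of the 4 values shown sits.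

The compounds shown leave open how the two cores would respond to other groups, such as a methoxy group or an amine in place of the chlorine.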